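A few compounds are considered here, and "the series" means these few. Any claim that something is new, unique, unknown or untested is made for them only; others in the source may bear on it.

Working notes on the series.

Compound 1 `O=C(CCCCCCc1ccc2ccccc2c1)c1ncc(-c2ccccn2)o1` in an assay for inhibition of Fatty-acid amide hydrolase 1 (Rattus norvegicus) (a higher number here means a weaker inhibitor, a lower number a stronger inhibitor), gives 11 nM. Compound 3 `CS(=O)(=O)c1ccc(CCCCCCC(=O)c2ncc(-c3ccccn3)o2)cc1` in this assay gives 19 nM; these two values sit within the usual scatter of each other. Among the measured compounds shown here, compound 2 `O=C(O)c1ccc(CCCCCCC(=O)c2ncc(-c3ccccn3)o2)cc1` is the one member of the set for which only a limit is known: in this assay compound 2 gives > 600 nM, a limit of the assay and not a number. For the measured compounds named here, compound 2 thus stands at the weak end of everything measured so far, as the single value at the limit of > 600 nM in this assay, at which 1 of the 3 values shown sits.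

Going by the values given here, the one step that has been measured from compound 2 is large: an at least 31-fold lower number from compound 2 to compound 3 (1.49 log units; beyond the scatter). Exchanging the carboxy for a group without a hydrogen-bond donor moved the compound from the limit to the range of compound 1.

Compound 4 `CSc1ccccc1CCCCCCC(=O)c1ncc(-c2ccccn2)o1` is not yet measured. It differs from compound 2 by 2-(methylsulfanyl)phenyl in place of 4-carboxyphenyl on a saturated chain carbon, six bonds along the chain from a carbonyl carbon. The carboxyphenyl, shared only by compound 2 among the measured compounds, leaves; the group that enters carries no hydrogen-bond donor, as in compound 1 and compound 3. The step from compound 2 to compound 3 therefore bears directly on this change, and a step of similar size and direction is expected: an at least 40-fold lower number from compound 2 to compound 4 (1.60 log units; beyond the scatter). For compound 4 the estimate in this assay is 15 nM, with a range from 5 nM to 60 nM.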

Compound 4, inhibition constant: 3.3 nM
Compound 4: middle estimate off by 4.5-fold (0.66 log units), on the high side, and the stated range ends above it.
By their numbers in this assay, from the lowest: compound 4; then compounds 1 and 3 (each within the scatter of the next). At a limit, above all of these: compound 2.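

The step of an at least 180-fold lower number from compound 2 to compound 4 (2.25 log units; beyond the scatter) shows that a second ring group with no hydrogen-bond donor, here carrying sulfur and none of the oxygens of methylsulfonyl, also leaves the limit behind at this place, on a saturated chain carbon, six bonds along the chain from a carbonyl carbon. In this assay compound 3 gives 19 nM and compound 4 gives 3.3 nM, so low numbers at this place are not tied to the methylsulfonyl group or to the ring substitution of compound 3. The size of the step remains a bound and not a measurement, since compound 2 is known only as a limit of the assay: the limit of > 600 nM in this assay, at which 1 of the 4 values shown sits.

The compounds shown leave open whether the weak result of compound 2 goes with the hydrogen-bond donor of the carboxy or with the carboxy group as a whole, which a methyl ester or a 4-hydroxyphenyl group at the same place would separate. They also leave the sulfur and the ring substitution of compound 4 unseparated, and a 4-(methylsulfanyl)phenyl or a 2-methoxyphenyl group would pull these two apart.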